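The source may hold more compounds than are shown below. What is called first, only, known or untested is meant among the compounds shown, and "the series" means these compounds.

The measured compounds are:

- compound 1, `COc1cccc(-c2c(C3=NN(C(=O)CCC(=O)O)C(c4ccc(Cl)cc4)C3)c(=O)[nH]c3ccccc23)c1`, which in an assay on cells (Oocyte) for negative allosteric modulation of glutamate receptor ionotropic, NMDA 2D (Rattus norvegicus), read by two-electrode voltage clamp (a higher number here means a weaker inhibitor, a lower number a stronger inhibitor), gives 4500 nM
- compound 2, `O=C(O)CCC(=O)N1N=C(c2c(-c3ccc(F)c(Cl)c3)c3ccccc3[nH]c2=O)CC1c1ccc(Cl)cc1`, which in this assay gives 1000 nM

For the measured compounds named here, compound 2 holds the lower of the two numbers, and its nearest neighbour is compound 1; the only measured step is a 4.5-fold lower number from compound 1 to compound 2 (0.65 log units; beyond the scatter), which swapped one whole aryl group for another and lies beyond the scatter.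

Compound 3, `O=C(O)CCC(=O)N1N=C(c2c(-c3ccc(Cl)c(Cl)c3)c3ccccc3[nH]c2=O)CC1c1ccc(Cl)cc1`, is not yet measured. It differs from compound 2 by chloro in place of fluoro on an aromatic carbon, so the change sits on the same ring that was exchanged in the step from compound 1 to compound 2, but is far smaller: one halogen for another, with nothing gained or lost in donors, acceptors or charge. Going by the values given here, because a 4.5-fold lower number from compound 1 to compound 2 (0.65 log units; beyond the scatter) shows that this ring matters, some movement is plausible, but no measured pair isolates a halogen swap on it, so the direction is uncertain. The expected step is a 1.3-fold lower number from compound 2 to compound 3 (0.10 log units; within the scatter), small and within the scatter. Compound 3 is therefore estimated at 800 nM, with a range from 300 nM to 2200 nM in this assay.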

Compound 3, half-maximal inhibitory concentration: 910 nM
The estimate for compound 3 lay 1.1-fold (0.06 log units) below the measured number; low and high end bracket the measured number.
By their numbers in this assay, from the lowest: compounds 3 and 2 (each within the scatter of the next); then compound 1.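

In this assay, for the compounds shown here, chloro in place of fluoro on this aromatic carbon, para to a large group and ortho to a chloro group, gives a 1.1-fold lower number from compound 2 to compound 3 (0.04 log units; within the scatter) and so leaves compound 2 and compound 3 indistinguishable, a comparison of two halogens at one position that the earlier compounds could not offer. The second halogen-bearing aryl group also stands clear of the methoxy-bearing one, since the 3,4-dichlorophenyl group in place of the 3-methoxyphenyl group gives a 4.9-fold lower number from compound 1 to compound 3 (0.69 log units; beyond the scatter) and shows that the step seen with the 3-chloro-4-fluorophenyl group is not confined to that single group. Nothing available bears on why these two halogens read alike here or why both aryl groups differ from the methoxy-bearing one.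

The compounds shown cannot tell whether a bromo, a trifluoromethyl or a plain hydrogen at this position would keep the number within the same scatter. They also leave open how much the neighbouring chloro group contributes, and whether a longer chain or an amide in place of the carboxylic acid would alter the reading.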